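The source may hold more compounds than are shown below. What is called first, only, known or untested is meant among the compounds shown, and "the series" means these compounds.

Working notes on the series. For the measured compounds named here, the three compounds measured so far share one core and differ only in the aryl group on the saturated ring carbon. Compound 1 `Cc1cc(O)c(C2=NN(c3ccc(S(N)(=O)=O)cc3)C(c3ccccc3O)C2)cc1Cl` gives 2780 nM in a functional assay on U-251 cells (Homo sapiens) for antiproliferative activity, with a stated time of 48 h; a higher number here means a weaker inhibitor of growth, a lower number a stronger inhibitor of growth. Compound 2 `Cc1cc(O)c(C2=NN(c3ccc(S(N)(=O)=O)cc3)C(c3ccccc3Cl)C2)cc1Cl` gives 2250 nM in this assay, a change of a 1.2-fold lower number from compound 1 to compound 2 (0.09 log units; within the scatter). Compound 3 `COc1ccc(C2CC(c3cc(Cl)c(C)cc3O)=NN2c2ccc(S(N)(=O)=O)cc2)cc1OC` gives 3710 nM in this assay; its number is the highest of the three, but the gaps to the others, a 1.3-fold higher number from compound 1 to compound 3 (0.13 log units; within the scatter) and a 1.6-fold higher number from compound 2 to compound 3 (0.22 log units; within the scatter), both stay within the scatter, so the three compounds cannot be separated on these data.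

Compound 4 `COc1ccc(C2CC(c3cc(Cl)c(C)cc3O)=NN2c2ccc(S(N)(=O)=O)cc2)c(OC)c1OC` is not yet measured. It differs from compound 3 by methoxy in place of hydrogen on an aromatic carbon. Going by the values given here, no measured step adds a group to the aryl ring on the saturated ring carbon; the two steps that touch that ring, a 1.3-fold higher number from compound 1 to compound 3 (0.13 log units; within the scatter) and a 1.6-fold higher number from compound 2 to compound 3 (0.22 log units; within the scatter), replace the whole aryl group and still remain within the scatter. The step from compound 3 to compound 4 is therefore expected to lie within the scatter as well, with no direction claimed, giving an expected 1.0-fold lower number from compound 3 to compound 4 (0.00 log units; within the scatter). On that basis compound 4 is estimated at 3700 nM in this assay, with a range from 1800 nM to 7600 nM.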

Compound 4, concentration for 50% growth inhibition: 2840 nM
For compound 4 the middle estimate is 1.3-fold (0.11 log units) above the measured one; low and high end bracket the measured number.
By their numbers in this assay, from the lowest: compounds 2, 1, 4 and 3 (each within the scatter of the next).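

Methoxy in place of hydrogen on an aromatic carbon, ortho to a large group and ortho to a methoxy group, is the first step in the series that adds a group to this aryl ring rather than replacing the whole ring, and in this assay it makes no separable difference (a 1.3-fold lower number from compound 3 to compound 4 (0.12 log units; within the scatter)). The whole-group replacements that lead to the 2,3,4-trimethoxyphenyl compound also stay within the scatter (a 1.3-fold higher number from compound 2 to compound 4 (0.10 log units; within the scatter); a 1.0-fold higher number from compound 1 to compound 4 (0.01 log units; within the scatter)), so 2-hydroxyphenyl, 2-chlorophenyl, 3,4-dimethoxyphenyl and 2,3,4-trimethoxyphenyl on the saturated ring carbon cannot be told apart on these numbers. No accompanying measurement speaks to the reason for these small steps.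

On these data alone, every group at this position is a substituted phenyl ring carrying hydroxy, chloro or methoxy, so it remains open whether an amine or a carboxylic acid on that ring, or a longer alkyl chain in place of the ring, would move the number beyond the scatter. The rest of the shared core is the same in all four compounds, so these data say nothing about changes there.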